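The source may report more compounds than this note shows. Statements on the series, on what has been measured and on what is new or still open speak of the compounds shown alone.

Measured compounds in the set:
compound 1, `CN1CCN(c2nc(Oc3ccc(C#N)cc3)nc(-c3ccc(N4C(=O)CSC4c4ccccc4)cc3)n2)CC1`: "not determined" (no result reported)
compound 2, `CN1CCN(c2nc(Oc3ccc(C#N)cc3)nc(-c3ccc(N4C(=O)CSC4c4ccc(Br)cc4)cc3)n2)CC1`: > 62.5 ug/mL
compound 3, `CN1CCN(c2nc(Oc3ccc(C#N)cc3)nc(-c3ccc(N4C(=O)CSC4c4ccc(F)cc4)cc3)n2)CC1`: "not determined" (no result reported)

The three share one core and differ only in one group on its outer aromatic ring. In an ADME assay on Vero cells (Chlorocebus sabaeus) for cytotoxicity, read by MTT assay, with a stated time of 72 h (a higher number here means a weaker inhibitor, a lower number a stronger inhibitor), compound 1 carries no result, "not determined" (no result reported). For compound 2 the assay reports only a limit, > 62.5 ug/mL. For compound 3 there is likewise no number, "not determined" (no result reported), so compound 3 stands nowhere on the numbers shown. For the measured compounds named here, the one measured entry in the whole set is the limit (the limit of > 62.5 ug/mL in this assay, at which 1 of the 3 values shown sits), and with two further entries empty no step between measured compounds can be read at all.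

Compound 4, `CN1CCN(c2nc(Oc3ccc(C#N)cc3)nc(-c3ccc(N4C(=O)CSC4c4ccc(O)cc4)cc3)n2)CC1`, differs from compound 3 by hydroxy in place of fluoro on an aromatic carbon. With one limit and two blanks there is nothing in the data from which a direction for this step could be taken; the expectation is therefore no step beyond the scatter, and a real chance that compound 4, like compound 2, returns only a limit in this assay rather than a number. Compound 4 is expected to give 62.5 ug/mL in this assay, within the range 30 ug/mL to 125 ug/mL.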

Compound 4, half-maximal inhibitory concentration: > 62.5 ug/mL
Compound 4 ended at the assay's limit; the forecaster's own chance of this, stated with the estimate: 70%; the middle value lies on the limit itself.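

In this assay compound 4 gives > 62.5 ug/mL as a limit, not a number. For the compounds shown here, compound 2 also stands at a limit, so no step between compound 2 and compound 4 can be read: the limit of > 62.5 ug/mL in this assay, at which 2 of the 4 values shown sit.

Going by these compounds, whether hydroxy and bromo differ at all in this assay stays open, since neither compound 2 nor compound 4 has a single number.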